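The compounds below may be only part of what the source reports. "The series", "measured", "known", "first", "only" and "open" are said of these compounds alone.

Compound 1, `CCCc1cc(C(=O)N[C@H](C)CCCc2cccnc2)ccc1-c1ccc(OC)c(OC)c1`, was tested in an assay (Canis lupus familiaris) for binding affinity to platelet-activating factor receptor (Homo sapiens), read by radioligand binding (a higher number here means a weaker inhibitor, a lower number a stronger inhibitor), where compound 1 gives 50 nM. Among the compounds with values here, the only other measured compound is compound 2, `O=C(NCCCCc1cccnc1)c1ccc(-c2ccccc2)c(-c2ccccc2)c1`, which in this assay gives 5 nM. Compound 1 therefore stands at the higher of the two numbers, the weaker binder, with compound 2 well below it by a gap wider than the usual scatter. The two differ in several places at once; the data do not single out which part of the structure accounts for that gap.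

Compound 3, `CCc1cc(C(=O)N[C@H](C)CCCc2cccnc2)ccc1-c1ccc(OC)c(OC)c1`, is the next compound to be measured. It differs from compound 1 in a single place: hydrogen in place of methyl on a saturated chain carbon, two bonds along the chain from an aromatic carbon. Within the data shown here, nothing among the measured compounds isolates the effect of such a trimming of a chain. The expected step is small, a 1.2-fold higher number from compound 1 to compound 3 (0.08 log units; within the scatter), likely within the scatter in either direction. Compound 3 is therefore estimated at 60 nM, within a range from 25 nM to 150 nM.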

Compound 3, half-maximal inhibitory concentration: 4 nM
Estimate against measurement, compound 3: 15-fold (1.18 log units) above; measured number outside the range, below it.
By their numbers in this assay, from the lowest: compounds 3 and 2 (each within the scatter of the next); then compound 1.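

Shortening the propyl group of compound 1 to the ethyl group of compound 3, with the rest of the structure unchanged, moves the number in this assay by a large step (a 13-fold lower number from compound 1 to compound 3 (1.10 log units; beyond the scatter)). This shows that the chain at this position is not a place where small trims pass unnoticed: removing a single carbon from its end gives a clearly stronger inhibitor, by a gap well beyond the scatter. No measurement shown gives a reason for this step.

This single step cannot tell whether the number would keep falling with a methyl group at this position or rise again with a longer chain such as butyl. On these data alone, how a hydroxyl group or an amine at the end of the ethyl chain would compare also stays open.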